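The compounds below may be only part of what the source reports. "The series", "measured", "known", "first", "only" and "open" are said of these compounds alone.

In a functional assay on Ehrlich cells (Mus musculus) for cytotoxicity, read by trypan blue exclusion, with a stated time of 2 h, tested at 10 ug/mL (on this read-out higher numbers stand for a stronger effect at the one concentration tested and lower numbers for a weaker effect), compound 1 `N#CC1=C(N)N(c2ccc(S(N)(=O)=O)cc2)C2=C(C(=O)CCC2)C1c1ccc(Cl)cc1Cl` gives 40%, compound 2 `N#CC1=C(NC(=S)Nc2ccc(Br)cc2)N(c2ccc(S(N)(=O)=O)cc2)C2=C(C(=O)CCC2)C1c1ccc(Cl)cc1Cl` gives 50% and compound 3 `N#CC1=C(NC(N)=O)N(c2ccc(S(N)(=O)=O)cc2)C2=C(C(=O)CCC2)C1c1ccc(Cl)cc1Cl` gives 20%.

Compound 3 stands lowest of the three numbers in this assay: a number 20 percentage points lower from compound 1 to compound 3 (beyond the scatter) and a number 30 percentage points lower from compound 2 to compound 3 (beyond the scatter). Compound 4 `N#CC1=C(N2C(=O)CCC2=O)N(c2ccc(S(N)(=O)=O)cc2)C2=C(C(=O)CCC2)C1c1ccc(Cl)cc1Cl` differs from compound 3 in one place: 2,5-dioxopyrrolidin-1-yl in place of ureido on a double-bonded ring carbon. Both measured steps that bear on this concern the group on that same nitrogen. They show that changing what sits there moves the read-out only modestly, and that the group of 10 heavy atoms in compound 2 went with the highest number, while the ureido of compound 3 went with the lowest. A modest rise is therefore expected in this assay. Compound 4 is expected to give 35%, with a range from 15% to 55%. For compound 4 this estimate means a number 15 percentage points higher from compound 3 to compound 4 (beyond the scatter).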

Compound 4, a percentage reported as activity, at one concentration (the size of the read-out at that concentration, not a potency): 20%
The estimate for compound 4 lay 15 percentage points above the measured number, and the stated range covers the measured number.
By their numbers in this assay, from the lowest: compounds 3 and 4 (each within the scatter of the next); then compounds 1 and 2 (each within the scatter of the next).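

In this assay, 2,5-dioxopyrrolidin-1-yl in place of ureido gives no change at the digits printed from compound 3 to compound 4 (within the scatter) on this double-bonded ring carbon, so a closed ring without hydrogen-bond donors matches the open ureido here. In place of amino, the same ring gives a number 20 percentage points lower from compound 1 to compound 4 (beyond the scatter) and, in place of the larger group with its aromatic ring, it gives a number 30 percentage points lower from compound 2 to compound 4 (beyond the scatter) in this assay. No measurement shown explains this match.

Still open, from the compounds shown here alone, is whether acetylamino or 2,6-dioxopiperidin-1-yl at this carbon would group with compound 3 or with compound 1.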